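Para-substituent swap on the aryl ring: compound 2 to compound 3

The source may report more compounds than this note shows. Statements on the series, on what has been measured and on what is new or still open speak of the compounds shown alone.

Measured so far:
compound 1, `CCOC(=O)c1nn(-c2ccc(O)cc2)c(=O)c2c(N)scc12`, 65.8%;
compound 2, `CCOC(=O)c1nn(-c2ccc(C(F)(F)F)cc2)c(=O)c2c(N)scc12`, 77.2%.

Compound 2 stands highest of the two numbers in an assay on CHO-K1 cells for displacement of a labelled ligand from adenosine receptor A1 (Homo sapiens), tested at 50 uM; on this read-out higher numbers stand for more inhibition at the one concentration tested (going by the name of the read-out) and lower numbers for less inhibition; its nearest neighbour is compound 1, with the step of a number 11.4 percentage points higher from compound 1 to compound 2 (beyond the scatter). Compound 3, `CCOC(=O)c1nn(-c2ccc([N+](=O)[O-])cc2)c(=O)c2c(N)scc12`, is not yet measured. The change from compound 2 to compound 3 is nitro in place of trifluoromethyl on an aromatic carbon. Among the compounds with values here, no measured step covers this exchange; the single known step concerns hydroxy against trifluoromethyl only. Given that, compound 3 is expected to stay close to compound 2, with a step of a number 5.2 percentage points lower from compound 2 to compound 3 (within the scatter), not beyond the scatter. Compound 3 is therefore estimated at 72%, within 58% to 85%.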

Compound 3, a percentage reported as inhibition, at one concentration (the size of the read-out at that concentration, not a potency): 73.4%
Beside the measured number, compound 3's estimate is 1.4 percentage points below it; the range from low to high includes it.
By their numbers in this assay, from the lowest: compounds 1, 3 and 2 (each within the scatter of the next, the first and the last beyond it).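

At this aromatic carbon, para to a large group, nitro and trifluoromethyl are not told apart in this assay, with a number 3.8 percentage points lower from compound 2 to compound 3 (within the scatter). Nitro also stays within the scatter of hydroxy, with a number 7.6 percentage points higher from compound 1 to compound 3 (within the scatter), so the one step beyond the scatter, a number 11.4 percentage points higher from compound 1 to compound 2 (beyond the scatter), separates only hydroxy and trifluoromethyl, and nitro is separated from neither. No measurement at hand bears on the reason for these results.

Open, as far as these compounds go, is how an amine, a carboxylic acid or a methoxy group would read at this carbon. Also open, from the compounds shown here alone, is whether any group here would fall beyond the scatter of both nitro and trifluoromethyl.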